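Series notes: indolyl for methoxyphenyl at the saturated ring carbon

The source may report more compounds than this note shows. Statements on the series, on what has been measured and on what is new or still open speak of the compounds shown alone.

Measured so far in a physicochemical assay for lipophilicity, at pH 7.4; a higher number here means a more lipophilic compound, a lower number a more polar compound:
compound 1, `CNC(=O)c1cc(C(=O)N[C@H]2[C@@H]3COC[C@@H]32)cc2c1OC[C@H]2c1cccc(OC)c1`: 3.2
compound 2, `CNC(=O)c1cc(C(=O)NC)c2c(c1)[C@](C)(c1ccccc1)CO2`: 3.4

In this assay compound 1 gives 3.2 and compound 2 gives 3.4; the two numbers lie within the scatter of each other, so no order between them is claimed. Compound 3, `CNC(=O)c1cc(C(=O)N[C@H]2[C@@H]3COC[C@@H]32)cc2c1OC[C@H]2c1cccc2[nH]ccc12`, is not yet measured. It differs from compound 1 in one place: 1H-indol-4-yl in place of 3-methoxyphenyl on a saturated ring carbon. Among the compounds with values here, no step between measured compounds covers this change. The step from compound 1 to compound 3 is expected to be small, if anything a slight fall, a number 0.10 log units lower from compound 1 to compound 3 (within the scatter). Compound 3 is estimated at 3.1, in the range 2.6 to 3.6.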

Compound 3, distribution coefficient: 3.1
Compound 3: middle estimate and measured number agree at the digits printed; the measured number falls inside the stated range.
By their numbers in this assay, from the lowest: compounds 3, 1 and 2 (each within the scatter of the next).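

In this assay, within the data shown here, 1H-indol-4-yl in place of 3-methoxyphenyl on a saturated ring carbon gives a number 0.10 log units lower from compound 1 to compound 3 (within the scatter) and is the first single-place change read at this position. A larger bicyclic group carrying a hydrogen-bond donor and no hydrogen-bond acceptor therefore leaves the number within the scatter of that of the 3-methoxyphenyl compound. Nothing measured here accounts for this result.

Open, going by these compounds, is whether an amine or a carboxylic acid on this saturated ring carbon would give a step beyond the scatter in this assay. Also open, on these data alone, is whether the same exchange would give a similar step on another core.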